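From 2-methoxyphenyl to 3,4-dichlorophenyl on the Shared Core

The source may hold more compounds than are shown below. What is called first, only, known or untested is meant among the compounds shown, and "the series" means these compounds.

Within the data shown here, compound 3 `CCC1(CCCCN2CCN(c3ccccc3OC)CC2)C(=O)Nc2ccccc21` gives 10 mg/kg in a functional assay on the whole organism (strain Wistar) with Rattus norvegicus as the target, with a stated time of 5 min (on this read-out higher numbers stand for an effect only at larger amounts of compound and lower numbers for an effect already at smaller amounts), the only plain number among the three measured compounds. Compound 1 `CCC1(CCCCN2CCN(c3cccc(OC)c3)CC2)C(=O)Nc2ccccc21` reaches only the limit > 20 mg/kg in this assay. Compound 2 `CCC1(CCCCN2CCN(c3ccc(C)c(Cl)c3)CC2)C(=O)Nc2ccccc21` likewise reaches only the limit > 20 mg/kg in this assay, so that (the limit of > 20 mg/kg in this assay, at which 2 of the 3 values shown sit). The step of an at least 2.0-fold lower number from compound 1 to compound 3 (0.30 log units; that floor lies within the scatter) and the step of an at least 2.0-fold lower number from compound 2 to compound 3 (0.30 log units; that floor lies within the scatter) point the same way, whereas a step that the two limits leave unreadable from compound 1 to compound 2. Compound 4 `CCC1(CCCCN2CCN(c3ccc(Cl)c(Cl)c3)CC2)C(=O)Nc2ccccc21` carries 3,4-dichlorophenyl in place of 2-methoxyphenyl on an amine nitrogen in a ring. The 3,4-dichlorophenyl that enters resembles the 3-chloro-4-methylphenyl of compound 2 more closely than the 2-methoxyphenyl of compound 3, so the step of an at least 2.0-fold lower number from compound 2 to compound 3 (0.30 log units; that floor lies within the scatter), taken in the reverse direction, is the closest guide. For compound 4 the expected outcome in this assay is therefore a higher dose, a 3.0-fold higher number from compound 3 to compound 4 (0.48 log units; beyond the scatter), and quite possibly only a limit rather than a number. Compound 4 is estimated at 30 mg/kg in this assay, with a range from 10 mg/kg to 100 mg/kg.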

Compound 4, minimum effective dose: > 20 mg/kg
Compound 4: a limit, no number; the forecaster's own chance of this, stated with the estimate: 65%; the middle value lies beyond the limit too.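

In this assay, 3,4-dichlorophenyl in place of 2-methoxyphenyl on the amine nitrogen in the ring gives an at least 2.0-fold higher number from compound 3 to compound 4 (0.30 log units; that floor lies within the scatter). Compound 4 ends at a limit rather than a number, so the steps that link it to compound 1 and compound 2 cannot be read, and swapping chloro for methyl on an aromatic carbon therefore tells nothing here. With a third aryl group now at the limit, compound 3 stays the only compound with a plain number, and the limit itself is now the commonest result: the limit of > 20 mg/kg in this assay, at which 3 of the 4 values shown sit.

From the compounds shown here alone, how far compound 1, compound 2 and compound 4 really lie from compound 3 stays open. Going by these compounds, it is also open whether a 2-chlorophenyl, a 2-ethoxyphenyl or a plain phenyl on the same nitrogen would give a number.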